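Working notes: aryl exchange leading to compound 4

This account rests on a few compounds, and the source may have more. Where it says the series, first, only, none or still open, it means among the compounds named here.

- compound 1 `COC1=C(C)C(=O)/C(=C(O)/C=C/c2ccccc2OC)C(=O)C1(C)C`: 2.8 ug/mL
- compound 2 `COC1=C(C)C(=O)/C(=C(O)/C=C/c2c(C)cccc2C)C(=O)C1(C)C`: 2.1 ug/mL
- compound 3 `COC1=C(C)C(=O)/C(=C(O)/C=C/c2cc(C)cc(C)c2)C(=O)C1(C)C`: 1.6 ug/mL

All three values come from a functional assay on KB cells (Homo sapiens) for cytotoxicity; a lower number here means that less compound is needed, a higher number that more compound is needed for the effect. Compound 3, at 1.6 ug/mL, stands within the scatter of both other compounds, so these numbers give no ranking.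

The next change leads to compound 4 `C=Cc1ccccc1/C=C/C(O)=C1/C(=O)C(C)=C(OC)C(C)(C)C1=O` and consists of 2-vinylphenyl in place of 3,5-dimethylphenyl on a double-bonded chain carbon bound to a double-bonded chain carbon. Three measured exchanges at the same place bear on it: a 1.3-fold lower number from compound 1 to compound 2 (0.12 log units; within the scatter), a 1.8-fold lower number from compound 1 to compound 3 (0.24 log units; within the scatter) and a 1.3-fold lower number from compound 2 to compound 3 (0.12 log units; within the scatter). None of them goes beyond the scatter. Going by the values given here, none of them brings in the double bond outside aromatic rings that 2-vinylphenyl carries, so the series offers no direct precedent for this group. With that caveat, no step beyond the scatter is expected in this assay, and no direction can be firmly assigned.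

The expected step is a 1.3-fold higher number from compound 3 to compound 4 (0.10 log units; within the scatter). The estimate for compound 4 is 2 ug/mL, with an expected range of 1 ug/mL to 4 ug/mL.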

Compound 4, concentration for half-maximal effect: 1.1 ug/mL
Estimate against measurement, compound 4: 1.8-fold (0.26 log units) above, within the range that was stated.
By their numbers in this assay, from the lowest: compounds 4, 3, 2 and 1 (each within the scatter of the next, the first and the last beyond it).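

In this assay, 2-vinylphenyl brings a double bond outside aromatic rings to this place on a double-bonded chain carbon bound to a double-bonded chain carbon, and against the two dimethylphenyl compounds the change stays within the scatter, with a 1.5-fold lower number from compound 3 to compound 4 (0.16 log units; within the scatter) and a 1.9-fold lower number from compound 2 to compound 4 (0.28 log units; within the scatter). Vinyl in place of methoxy on an aromatic carbon gives the first step in the series beyond the scatter, though a modest one, with a 2.5-fold lower number from compound 1 to compound 4 (0.41 log units; beyond the scatter). No evidence at hand accounts for this step.

On these data alone, what an amine or a carboxylic acid on the aryl ring would do in this assay stays open, as does the outcome of a longer chain in place of vinyl. The compounds shown also leave open whether the step from methoxy to vinyl would hold on any core other than this one.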